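Bromo to Hydrogen on a Shared Core

The compounds below may be only part of what the source reports. "The series", "measured", "known", "first", "only" and "open" are said of these compounds alone.

On these data alone, the study examines three measured compounds and one whose value is still open. Compound 1 `COc1ccc(Cn2cc(/C=N\NC(=O)c3c[nH]c4ccccc34)c3cc(OC)ccc32)cc1` gives 19100 nM in a functional assay on DU-145 cells (Homo sapiens) for cytotoxicity; a lower number here means a stronger inhibitor, a higher number a weaker inhibitor. Compound 2 `COc1ccc(Cn2cc(/C=N\NC(=O)c3c[nH]c4ccc(Br)cc34)c3cc(OC)ccc32)cc1` gives 84400 nM in this assay, and compound 3 `O=C(N/N=C\c1cn(Cc2ccc(Cl)cc2)c2ccc(Br)cc12)c1c[nH]c2ccccc12` gives 3600 nM, the lowest number of the three, with compound 1 the nearest of the others. The difference between the cores of compound 2 and compound 3 is not broken down here.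

One change appears twice. Between compound 2 and compound 1 it is hydrogen in place of bromo on an aromatic carbon, and the measured step is a 4.4-fold lower number from compound 2 to compound 1 (0.65 log units; beyond the scatter). Compound 4 `O=C(N/N=C\c1cn(Cc2ccc(Cl)cc2)c2ccccc12)c1c[nH]c2ccccc12` carries the same change made on compound 3: hydrogen in place of bromo on an aromatic carbon.

Compound 4 is therefore expected to give a lower number than compound 3, with an estimated step of a 3.0-fold lower number from compound 3 to compound 4 (0.48 log units; beyond the scatter), an expectation that rests on compound 1 and compound 2 because of a 4.4-fold lower number from compound 2 to compound 1 (0.65 log units; beyond the scatter). The estimate for compound 4 in this assay is 1200 nM, expected to lie between 500 nM and 3000 nM.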

Compound 4, half-maximal inhibitory concentration: 52100 nM
For compound 4 the middle estimate is 43-fold (1.64 log units) below the measured one, and the stated range ends below it.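

Carried to a second core, hydrogen in place of bromo on an aromatic carbon gives a 14-fold higher number from compound 3 to compound 4 (1.16 log units; beyond the scatter) in this assay and reverses the direction of the earlier step, so the two cores disagree: the same change on two cores in this assay, a 4.4-fold lower number (0.65 log units; beyond the scatter) from compound 2 to compound 1 and a 14-fold higher number (1.16 log units; beyond the scatter) from compound 3 to compound 4, 64-fold (1.81 log units) apart, beyond the scatter of two such steps.

In this series, then, neither the direction nor the size of the change on one core held on the other. The result does not show which difference between the cores is responsible: the bromo stands in a different part of the molecule in compound 3 than in compound 2, the cores also differ elsewhere, and two pairs set no rule for any further core.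

The compounds shown carry only bromo or hydrogen at the changed places, so it remains open how fluoro, a nitrile or an amine would behave there on either core. Also open, on these data alone, is whether the opposite steps would recur outside this assay on any other cells.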